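The source may report more compounds than this note shows. Statements on the series, on what has been measured and on what is new or still open speak of the compounds shown alone.

Working notes on the series. In an ADME assay on HepG2 cells (Homo sapiens) for cytotoxicity, read by MTT assay, with a stated time of 72 h (on this read-out higher numbers stand for lower toxicity in this test and lower numbers for higher toxicity in this test), compound 1 `Cc1ccc(-c2cc3nc(NCC(C)C)[nH]c(=O)c3s2)cc1` gives 21600 nM. Compound 2 `CC(C)(C)Nc1nc2cc(-c3ccc(Br)cc3)sc2c(=O)[nH]1` gives 1400 nM, the lower of the two numbers and so the higher toxicity in this test, and its gap to compound 1 lies beyond the scatter. Within the data shown here, these two compounds differ in more than one place, so no measured single-place step is available and the gap cannot be assigned to one change.

Compound 3 `COc1ccc(-c2cc3nc(NC(C)(C)C)[nH]c(=O)c3s2)cc1` has yet to be measured in this assay. It departs from compound 2 in one place: methoxy in place of bromo on an aromatic carbon, with methoxy in place of bromo on an aromatic carbon, para to a large group. Among the measured compounds shown here, a shift toward a higher number is expected, on the weak ground that compound 2 at 1400 nM holds the lower of the only two values. The expected move is modest, an estimated 2.9-fold higher number from compound 2 to compound 3 (0.46 log units; beyond the scatter), and a result within the scatter would not be surprising. For compound 3 the estimated value is 4000 nM, with an expected range of 1200 nM to 15000 nM.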

Compound 3, half-maximal cytotoxic concentration: 32300 nM
Compound 3: middle estimate off by 8.1-fold (0.91 log units), on the low side, outside the stated range (above it).
By their numbers in this assay, from the lowest: compound 2; then compounds 1 and 3 (each within the scatter of the next).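

In this assay, among these compounds, a single-place change can be read for the first time: methoxy in place of bromo on an aromatic carbon, para to a large group, gives a 23-fold higher number from compound 2 to compound 3 (1.36 log units; beyond the scatter) and so moves toward lower toxicity in this test. The earlier gap between two compounds differing in more than one place could not be assigned to any one change, whereas this step is tied to this position alone, with the rest of the structure unchanged. No measured property of either group accompanies the step, so the data give no account of its size.

The two groups alone do not tell whether the number depends on something particular to methoxy or on the departure of bromo, and chloro, fluoro, hydroxy or ethoxy at this position would separate those readings. Among the compounds shown here, it also remains open whether a step of this size would recur with the amine chain of compound 1 in place of the one shared by compound 2 and compound 3, since a single pair defines no trend.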